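The source may report more compounds than this note shows. Statements on the series, on what has been measured and on what is new or still open speak of the compounds shown alone.

Three compounds share one core and differ at two spots. Compound 1 `CCC(CC)OC(=O)C1=C(C)NC(=O)NC1c1ccco1` gives 2% in an assay on membranes from CHO cells for displacement of a labelled ligand from adenosine receptor A1 (Homo sapiens), read by scintillation counting, with a stated time of 60 min, tested at 1 uM; on this read-out lower numbers stand for less inhibition and higher numbers for more inhibition at the one concentration tested (going by the name of the read-out). Compound 2 `CCC(C)OC(=O)C1=C(C)NC(=O)NC1c1ccco1` gives 6% in this assay, and compound 3 `CCC(CC)OC(=O)C1=C(C)NC(=O)NC1c1ccsc1` gives 22% in this assay. The change hydrogen in place of methyl on a saturated chain carbon, two bonds along the chain from an oxygen next to a carbonyl group made a number 4 percentage points higher from compound 1 to compound 2 (within the scatter). The change thiophen-3-yl in place of furan-2-yl on a saturated ring carbon made a number 20 percentage points higher from compound 1 to compound 3 (beyond the scatter). Compound 4 `CCC(C)OC(=O)C1=C(C)NC(=O)NC1c1ccsc1` is not yet measured; it carries the change (hydrogen in place of methyl on a saturated chain carbon, two bonds along the chain from an oxygen next to a carbonyl group), the same change that turned compound 1 into compound 2, at a place described in the same words. Because a number 4 percentage points higher from compound 1 to compound 2 (within the scatter), the expected step is a number 2 percentage points higher from compound 3 to compound 4 (within the scatter), resting on that single earlier pair. Compound 4 is estimated at 24% in this assay, with the likely range from 10% to 38%.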

Compound 4, a percentage reported as inhibition, at one concentration (the size of the read-out at that concentration, not a potency): 5%
For compound 4 the middle estimate is 19 percentage points above the measured one; the whole stated range lies above it.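

Putting hydrogen in place of methyl gave a number 17 percentage points lower from compound 3 to compound 4 (beyond the scatter), which does not match the earlier step on the other core: the same change on two cores in this assay, a number 4 percentage points higher (within the scatter) from compound 1 to compound 2 and a number 17 percentage points lower (beyond the scatter) from compound 3 to compound 4, 21 percentage points apart, beyond the scatter of two such steps. Putting thiophen-3-yl in place of furan-2-yl gave a number 1 percentage points lower from compound 2 to compound 4 (within the scatter), so this change did not carry over unchanged either: the same change on two cores in this assay, a number 20 percentage points higher (beyond the scatter) from compound 1 to compound 3 and a number 1 percentage points lower (within the scatter) from compound 2 to compound 4, 21 percentage points apart, beyond the scatter of two such steps. In these four compounds, the size of each step depends on the group at the other spot, but this does not show why, nor does it give a rule for other compounds.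

On these data alone, how a longer chain in place of pentan-3-yl, or a phenyl ring in place of thiophen-3-yl, would behave stays open. So does whether the same dependence appears on other cores.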